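Hydroxyphenyl hydrazones on the shared core: compound 4

A few compounds are considered here, and "the series" means these few. Any claim that something is new, unique, unknown or untested is made for them only; others in the source may bear on it.

The series keeps the core of compound 1 `COc1ccc(/C=N/NC(=O)CSc2nnc(-c3ccncc3)o2)cc1` and varies the aryl group on the carbon with a double bond to nitrogen. In a functional assay on SW 1116 cells (Homo sapiens) for cytotoxicity, read by MTT assay, with a stated time of 48 h (on this read-out lower numbers stand for stronger inhibition and higher numbers for weaker inhibition), compound 1 gives 20300 nM, the highest number of the three measured here. Compound 2 `O=C(CSc1nnc(-c2ccncc2)o1)N/N=C/c1cc(Br)ccc1O` gives 8150 nM in this assay, and compound 3 `O=C(CSc1nnc(-c2ccncc2)o1)N/N=C/c1cc(Cl)cc(Cl)c1O` gives 5030 nM. Both measured steps from compound 1 lower the number beyond the scatter: a 2.5-fold lower number from compound 1 to compound 2 (0.40 log units; beyond the scatter) and a 4.0-fold lower number from compound 1 to compound 3 (0.61 log units; beyond the scatter), while a 1.6-fold lower number from compound 2 to compound 3 (0.21 log units; within the scatter).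

Compound 4 `O=C(CSc1nnc(-c2ccncc2)o1)N/N=C/c1ccc(O)c(O)c1` is unmeasured. Its change from compound 1 is 3,4-dihydroxyphenyl in place of 4-methoxyphenyl on a carbon with a double bond to nitrogen. Among the measured compounds shown here, no measured step has this exact change; the two relevant steps both replace 4-methoxyphenyl with a hydroxy-bearing phenyl that also carries halogen, and each lowers the number modestly. Compound 4 carries hydroxyls but no halogen, so the halogen-bearing steps serve only as a rough guide. For the measured compounds named here, a modest lowering is therefore expected in this assay, of about a 2.0-fold lower number from compound 1 to compound 4 (0.31 log units; beyond the scatter), with considerable uncertainty given the single change type available.

Compound 4 is estimated at 10000 nM in this assay, within a range of 4000 nM to 30000 nM.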

Compound 4, half-maximal inhibitory concentration: 1540 nM
Compound 4: the middle estimate sits 6.5-fold (0.81 log units) above what was measured; the measured number lies below the stated range.
By their numbers in this assay, from the lowest: compound 4; then compounds 3 and 2 (each within the scatter of the next); then compound 1.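

In this assay, among the compounds shown here, halogen on the aryl group is not required for a lower number at this position: 3,4-dihydroxyphenyl in place of 4-methoxyphenyl gives a 13-fold lower number from compound 1 to compound 4 (1.12 log units; beyond the scatter), the only large step so far. The same group also outperforms both halogen-bearing hydroxyphenyl groups, with a 3.3-fold lower number from compound 3 to compound 4 (0.51 log units; beyond the scatter) and a 5.3-fold lower number from compound 2 to compound 4 (0.72 log units; beyond the scatter), which makes compound 4 the most potent of the four here, although compound 2 and compound 3 remain within the scatter of each other. The data shown give no measured basis for explaining the size of these steps.

From the compounds shown here alone, because compound 4 differs from compound 2 and compound 3 in both its hydroxyl pattern and its lack of halogen, the contribution of each remains open, as does whether a single hydroxyl on the phenyl ring would be enough. Going by these compounds, it is also open whether an amine or a carboxylic acid in place of the hydroxyls would keep the number this low on the shared core.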